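Two Cytotoxicity Limits and an Isopropoxy Swap

A few compounds are considered here, and "the series" means these few. Any claim that something is new, unique, unknown or untested is made for them only; others in the source may bear on it.

Measured so far:
compound 1 `CCOC(=O)CCCCCOc1cccc(CN(C(=O)c2ccc(-c3cccc(N(C)C)c3)cc2)C(C)C)c1`: > 26000 nM
compound 2 `CCOC(=O)CCCCCOc1cccc(CN(C(=O)c2ccc(-c3cccc(-c4ccccc4)c3)cc2)C(C)C)c1`: > 26000 nM

In an ADME assay on HepG2 cells (Homo sapiens) for cytotoxicity, read by CellTiter-Glo and resazurin assay, with a stated time of 72 h (a higher number here means that more compound is needed for the effect, a lower number that less compound is needed), compound 1 gives > 26000 nM, which is a limit of the assay rather than a number. Compound 2 likewise gives > 26000 nM, again only a limit. The step that the two limits leave unreadable from compound 1 to compound 2 can therefore not be read in size. Within the data shown here, compound 2 thus stands at a limit, as does the one other value shown, (the limit of > 26000 nM in this assay, at which 2 of the 2 values shown sit).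

Compound 3 `CCOC(=O)CCCCCOc1cccc(CN(C(=O)c2ccc(-c3cccc(OC(C)C)c3)cc2)C(C)C)c1` differs from compound 2 by isopropoxy in place of phenyl on an aromatic carbon. Among the measured compounds shown here, only one measured step bears on this change, the one from compound 1 to compound 2, and its size is unreadable, so in this assay no step beyond the scatter is expected. Compound 3 is expected to give 40000 nM, between 15000 nM and 120000 nM, most likely again only as a limit. The step that the limit leaves unreadable from compound 2 to compound 3 is thus expected to lie within the scatter.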

Compound 3, half-maximal effective concentration: > 26000 nM
Compound 3: a limit, no number; the forecaster's own chance of this, stated with the estimate: 80%; the middle value lies beyond the limit too.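

In this assay compound 3 gives > 26000 nM as a limit, not a number. Among these compounds, compound 1, compound 2 and compound 3 therefore yield no step that can be read. From the compounds shown here alone, whether dimethylamino, phenyl and isopropoxy differ at all in this assay stays open.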